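Changing One Ester Group on a Shared Core

The source may hold more compounds than are shown below. What is called first, only, known or untested is meant among the compounds shown, and "the series" means these compounds.

Three compounds have been measured in an ADME assay on a cell-free system (plasma, Homo sapiens) for metabolic stability, with Plasma (Rattus norvegicus) as the target, read by HPLC, at pH 7.4; on this read-out higher numbers stand for a longer-lived compound and lower numbers for a shorter-lived compound:

compound 1, `CC(=O)Oc1ccccc1C(=O)O[C@H]1CO[C@H]2[C@@H]1OC[C@H]2OC(=O)C1CC1`, giving 0.015 h;
compound 2, `CC(=O)Oc1ccccc1C(=O)O[C@H]1CO[C@H]2[C@@H]1OC[C@H]2OC(=O)c1ccccc1C`, giving 0.0138 h;
compound 3, `CCOc1cc(OCC)cc(C(=O)O[C@@H]2CO[C@H]3[C@@H]2OC[C@@H]3OC(=O)c2ccccc2OC(C)=O)c1`, giving 0.0283 h.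

Compound 2 has the lowest number of the three. Its nearest neighbour is compound 1, with a 1.1-fold lower number from compound 1 to compound 2 (0.04 log units; within the scatter). The gap to compound 3 is larger: a 2.1-fold higher number from compound 2 to compound 3 (0.31 log units; beyond the scatter), a modest step beyond the scatter.

The next compound, compound 4, `CC(=O)Oc1ccccc1C(=O)O[C@H]1CO[C@H]2[C@@H]1OC[C@H]2OC(=O)c1cccc(CO[N+](=O)[O-])c1`, differs from compound 2 in one place: 3-((nitrooxy)methyl)phenyl in place of 2-methylphenyl on a carbonyl carbon. Two earlier steps bear on this change. Each of them also exchanged the group on that same carbonyl carbon. From cyclopropyl to 2-methylphenyl the number hardly moved (a 1.1-fold lower number from compound 1 to compound 2 (0.04 log units; within the scatter)), and from 2-methylphenyl to 3,5-diethoxyphenyl it rose only modestly (a 2.1-fold higher number from compound 2 to compound 3 (0.31 log units; beyond the scatter)). For the measured compounds named here, exchanging one aryl group for another on this carbonyl carbon has therefore produced at most a modest step, and no measured compound carries a nitrooxy group that could point elsewhere.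

Compound 4 is consequently expected to remain close to compound 2, with the step estimated as a 1.3-fold higher number from compound 2 to compound 4 (0.12 log units; within the scatter). The estimate for compound 4 in this assay is 0.018 h, within a range from 0.009 h to 0.04 h.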

Compound 4, half-life: 0.045 h
For compound 4 the middle estimate is 2.5-fold (0.40 log units) below the measured one; the measured number lies above the stated range.
By their numbers in this assay, from the lowest: compounds 2, 1, 3 and 4 (each within the scatter of the next, the first and the last beyond it).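

In this assay, the group on this carbonyl carbon turns out to have more influence than the first three compounds suggested: the step of a 3.3-fold higher number from compound 2 to compound 4 (0.51 log units; beyond the scatter) is larger than any step among those three, and a 3.0-fold higher number from compound 1 to compound 4 (0.48 log units; beyond the scatter) is also beyond the scatter, though both remain modest. The new group does not stand apart from every other group, however: with a 1.6-fold higher number from compound 3 to compound 4 (0.20 log units; within the scatter), which lies within the scatter, 3-((nitrooxy)methyl)phenyl and 3,5-diethoxyphenyl cannot be told apart here, even though the two groups are quite different. Nothing measured here explains why the number rises when 3-((nitrooxy)methyl)phenyl replaces 2-methylphenyl or cyclopropyl.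

For the compounds shown here, with only one nitrooxy compound in the set, it remains open whether the nitrooxy group itself matters or whether other groups of this shape would give the same number. A 3-(hydroxymethyl)phenyl or a 3-carboxyphenyl group on the same carbonyl carbon would help separate these possibilities, since each keeps the aromatic ring but has no nitrooxy group.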